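A few compounds are considered here, and "the series" means these few. Any claim that something is new, unique, unknown or untested is made for them only; others in the source may bear on it.

Of the compounds shown here, three of a shared core have been measured in a functional assay on ileum for antagonist activity at histamine H1 receptor (Cavia porcellus); on this read-out lower numbers stand for tighter binding and higher numbers for weaker binding. Compound 1 `N/C(=N\C(=O)CCc1c[nH]c2ccccc12)NCCCc1c[nH]cn1` gives 398 nM. Compound 2 `CC(=O)/N=C(\N)NCCCc1c[nH]cn1`, which carries the smallest group on the acyl side, gives 8510 nM. Compound 3 `CN(CCC(=O)/N=C(\N)NCCCc1c[nH]cn1)C(=O)c1cc2ccccc2[nH]1` gives 3020 nM. Of these three numbers, compound 2 stands highest: compound 3 lies clearly below it, and compound 1 lies far below it, both gaps being beyond the usual scatter of this assay. Seen together, the two compounds that carry a larger group on the acyl side sit at lower numbers than compound 2, though only three compounds are at hand and no pair of them differs in a single place.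

Compound 4 `CCCC(=O)/N=C(\N)NCCCc1c[nH]cn1` is the next compound to be measured in this assay. It differs from compound 2 by ethyl in place of hydrogen on a saturated chain carbon bound to a carbonyl carbon. For the measured compounds named here, no pair of measured compounds shows this kind of single change, so the size of the step can only be expected from the spread of the three values. A modest move toward a lower number is expected, from compound 2 to compound 4 a 2.4-fold lower number from compound 2 to compound 4 (0.39 log units; beyond the scatter), since compound 1 at 398 nM and compound 3 at 3020 nM both carry more on the acyl side and sit below compound 2. Compound 4 is therefore estimated at 3500 nM, within a range of 1200 nM to 9000 nM.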

Compound 4, dissociation constant: 3550 nM
For compound 4 the middle estimate is 1.0-fold (0.01 log units) below the measured one; the range from low to high includes it.
By their numbers in this assay, from the lowest: compound 1; then compounds 3 and 4 (each within the scatter of the next); then compound 2.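

For the compounds shown here, this is the first step that changes one place only, so the effect of a longer chain on the acyl side can now be read directly rather than guessed from compounds that differ in several places. In this assay, ethyl in place of hydrogen on a saturated chain carbon bound to a carbonyl carbon gives a 2.4-fold lower number from compound 2 to compound 4 (0.38 log units; beyond the scatter) and is thus a modest change, yet one that exceeds the usual scatter. The entering ethyl has no ring and no hydrogen-bond donors or acceptors, so this step shows that a small addition of plain chain carbons is enough to shift the number, though no measurement here bears on the reason for the shift.

A single step cannot show whether the trend continues, so a longer chain such as pentyl, a branched chain such as isopropyl, or a chain ending in an amine or a carboxylic acid could lower the number further, leave it unchanged or raise it. Compounds 1 and 3 differ from compound 4 in more than one place, so the contribution of each part of their larger acyl groups remains unresolved.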